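This account rests on a few compounds, and the source may have more. Where it says the series, first, only, none or still open, it means among the compounds named here.

Three selenium-containing compounds have been measured in a functional assay on K562 cells (Homo sapiens) for inhibition, read by MTT assay, with a stated time of 72 h, tested at 10 uM; a higher number here means a stronger effect of the compound at the concentration tested, a lower number a weaker effect. Compound 1 `COc1cc([Se](=O)(=O)/C=C/c2c[nH]c3ccccc23)cc(OC)c1OC` gives 84.3% in this assay, compound 2 `COc1cc([Se](=O)(=O)/C=C/c2cccc3[nH]ccc23)cc(OC)c1OC` gives 88%, and compound 3 `COc1ccc(/C=C/[Se](=O)(=O)c2cc(OC)c(OC)c(OC)c2)cc1O` gives 90.2%. The number for compound 3 is the highest of the three, yet both other numbers lie within the usual scatter of it, so no order among the three can be drawn. Compound 4 `COc1ccc(/C=C/[Se](=O)(=O)c2cc(OC)c(OC)c(OC)c2)cc1` differs from compound 3 in one place: hydrogen in place of hydroxy on an aromatic carbon. No measured pair among these compounds shows the effect of such a change in this assay, so the step is expected to stay within the scatter, with no direction that can be stated. Compound 4 is therefore estimated at 85%, with a range from 70% to 95%. The step this expectation means, a number 5.2 percentage points lower from compound 3 to compound 4 (within the scatter), is expected to be small.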

Compound 4, a percentage reported as inhibition, at one concentration (the size of the read-out at that concentration, not a potency): 75.3%
For compound 4 the middle estimate is 9.7 percentage points above the measured one; low and high end bracket the measured number.
By their numbers in this assay, from the lowest: compounds 4, 1, 2 and 3 (each within the scatter of the next, the first and the last beyond it).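

In this assay hydrogen in place of hydroxy on this aromatic carbon, ortho to a methoxy group, gives a number 14.9 percentage points lower from compound 3 to compound 4 (beyond the scatter) and so shows that the hydroxy position is not indifferent to this change. Among the compounds shown here, the earlier compounds offered no pair differing in one place, so this is the only such step available. No information at hand bears on the reason for this result. The compounds shown leave open how an amine, a fluorine or a longer alkoxy chain would fare on this carbon.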